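This account rests on a few compounds, and the source may have more. Where it says the series, first, only, none or still open, it means among the compounds named here.

Among the compounds with values here, in a functional assay on the whole organism (strain Kunming) with Mus musculus as the target, in the formalin test, with a stated time of 0.5 h (a lower number here means that less compound is needed, a higher number that more compound is needed for the effect), only two compounds have numbers so far: compound 1 `COc1ccccc1/C=C/C(=O)OC/C=C/c1cc(OC)c(OC)cc1OC` gives 113 mg/kg and compound 2 `COc1cc(OC)c(OC)cc1/C=C/COC(=O)/C=C/c1ccc(OC)c(OC)c1` gives 93.3 mg/kg. Compound 2 therefore has a single neighbour to be compared with, and the comparison does not separate them. The measured step is a 1.2-fold lower number from compound 1 to compound 2 (0.08 log units; within the scatter), so the two numbers count as the same result.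

Compound 3 `COc1cc(OC)c(OC)cc1/C=C/COC(=O)/C=C/c1ccc(OC)c(OC)c1OC` is compound 2 with one further alteration: methoxy in place of hydrogen on an aromatic carbon. In words, this is methoxy in place of hydrogen on an aromatic carbon. Within the data shown here, the change falls in the same part of the molecule that already differs between compound 1 and compound 2, so that one step is the only evidence that bears on it. It is thin evidence, a single pair, but it offers no reason to expect a large effect from altering the methoxy groups there. No shift beyond the scatter is therefore expected in this assay, and the estimated step is a 1.0-fold lower number from compound 2 to compound 3 (0.02 log units; within the scatter). For compound 3 the expected value is 90 mg/kg, with an estimated range from 45 mg/kg to 180 mg/kg.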

Compound 3, dose for half-maximal effect: 78.4 mg/kg
Compound 3: the middle estimate sits 1.1-fold (0.06 log units) above what was measured; low and high end bracket the measured number.
By their numbers in this assay, from the lowest: compounds 3, 2 and 1 (each within the scatter of the next).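

In this assay, putting methoxy in place of hydrogen on an aromatic carbon gives a 1.2-fold lower number from compound 2 to compound 3 (0.08 log units; within the scatter), so the two compounds count as the same result. This pair isolates a single added group, at a place ortho to a large group, ortho to a methoxy group and meta to a methoxy group, and shows that a methoxy group there, with its 2 heavy atoms, produces no shift that can be told from the usual scatter of this whole-animal test. Nothing measured alongside these numbers offers an explanation for this outcome, so the result stands only as an observation about this one pair.

Whether a different group at this same place, such as a hydroxyl group, a fluorine atom or an amine, would move the number beyond the scatter remains open, since methoxy and hydrogen are the only two cases shown there. As far as these compounds go, it is also open whether any change elsewhere, for example an amide in place of the ester that joins the two parts of the molecule, would separate compounds that so far all read alike.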